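Para-substituent swaps on the benzyl triazole amide series

This account rests on a few compounds, and the source may have more. Where it says the series, first, only, none or still open, it means among the compounds named here.

Measured compounds:
Compound 1, `CC(C)n1ncc2c(C(=O)NCc3cn(Cc4ccc(C(F)(F)F)cc4)nn3)cccc21`: in a functional assay on HepG2 cells (Homo sapiens) for inhibition, read by MTT assay, with a stated time of 72 h (on this read-out lower numbers stand for stronger inhibition and higher numbers for weaker inhibition), compound 1 reaches only the assay limit > 40000 nM.
Compound 2, `CC(C)n1ncc2c(C(=O)NCc3cn(Cc4ccc(C#N)cc4)nn3)cccc21`: compound 2 likewise gives the limit > 40000 nM.
Compound 3, `COc1ccc(Cn2cc(CNC(=O)c3cccc4c3cnn4C(C)C)nn2)cc1`: compound 3 gives the limit > 40000 nM.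

Compound 3 stands where every value of the series sits, at the limit of > 40000 nM in this assay, at which 3 of the 3 values shown sit; no number separates it from compound 1 or compound 2. Compound 4, `CC(C)n1ncc2c(C(=O)NCc3cn(Cc4ccc(C(C)(C)C)cc4)nn3)cccc21`, differs from compound 3 by tert-butyl in place of methoxy on an aromatic carbon. Within the data shown here, the steps that bear on this position, a step that the two limits leave unreadable from compound 1 to compound 3 and a step that the two limits leave unreadable from compound 2 to compound 3, are both unreadable, as is a step that the two limits leave unreadable from compound 1 to compound 2. Nothing therefore points to a readable step in this assay, in either direction, and the expected step that the limit leaves unreadable from compound 3 to compound 4 is essentially none. Compound 4 is estimated at 45000 nM, in the range 15000 nM to 120000 nM, most likely again reported as a limit.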

Compound 4, half-maximal inhibitory concentration: > 40000 nM
Compound 4 was reported as a limit; the forecaster's own chance of this, stated with the estimate: 80%; the middle value does not contradict the limit.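

Among these compounds, compound 4 gives the limit > 40000 nM and no step to it from compound 1, compound 2 or compound 3 can be read. The compounds shown leave open which change, if any, would give a measurable value.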